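The compounds below may be only part of what the source reports. "The series", "measured", "known", "first", "only" and "open" are said of these compounds alone.

Measured compounds:
compound 1 `CC[C@H](C)[C@@H]1C(=O)N[C@H](C2Cc3ccccc3C2)C(=O)N1[C@@H](C(=O)N(C)C)c1ccc(C)nc1C` — 0.0794 nM
compound 2 `CC(C)C[C@@H]1C(=O)N[C@H](C2Cc3ccccc3C2)C(=O)N1[C@@H](C(=O)N(C)C)c1ccc(O)nc1` — 3.16 nM

The study concerns an assay on isolated protein for displacement of a labelled ligand from Oxytocin receptor (Homo sapiens); a higher number here means a weaker inhibitor, a lower number a stronger inhibitor. Of the compounds shown here, two have been measured. Compound 1 `CC[C@H](C)[C@@H]1C(=O)N[C@H](C2Cc3ccccc3C2)C(=O)N1[C@@H](C(=O)N(C)C)c1ccc(C)nc1C` gives 0.0794 nM in this assay, and compound 2 `CC(C)C[C@@H]1C(=O)N[C@H](C2Cc3ccccc3C2)C(=O)N1[C@@H](C(=O)N(C)C)c1ccc(O)nc1` gives 3.16 nM. Compound 1 thus holds the lowest number of the two, and its nearest neighbour, compound 2, stands a long way above it, well beyond the scatter; the two differ in more than one place, so the gap between them is not tied to a single change.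

Compound 3 `CC[C@H](C)[C@@H]1C(=O)N[C@H](C2Cc3ccccc3C2)C(=O)N1[C@@H](C(=O)N(C)C)c1cnc(C)cc1C` has not yet been measured in this assay. It is built from compound 1 by the change 4,6-dimethylpyridin-3-yl in place of 2,6-dimethylpyridin-3-yl on a saturated chain carbon bound to an amide-type nitrogen in a ring and a carbonyl carbon: the two have the same atoms, joined differently, and the group at that place keeps its count of ring atoms, donors and acceptors. For the measured compounds named here, no measured pair in the set shows the effect of such a rearrangement, so there is no step to lean on.

In the absence of such a comparison, the estimate for compound 3 is a small loss from the number of compound 1, the step from a 2.5-fold higher number from compound 1 to compound 3 (0.40 log units; beyond the scatter) expected to lie close to the scatter, and the expected value for compound 3 is 0.2 nM, with a range from 0.04 nM to 1 nM.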

Compound 3, inhibition constant: 0.0398 nM
The estimate for compound 3 lay 5.0-fold (0.70 log units) above the measured number, outside the stated range (below it).
By their numbers in this assay, from the lowest: compounds 3 and 1 (each within the scatter of the next); then compound 2.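

In this assay, 4,6-dimethylpyridin-3-yl in place of 2,6-dimethylpyridin-3-yl on a saturated chain carbon bound to an amide-type nitrogen in a ring and a carbonyl carbon gives a 2.0-fold lower number from compound 1 to compound 3 (0.30 log units; within the scatter) and so leaves the reading at this place unchanged within the scatter. For the compounds shown here, this is the first comparison in the set that isolates one change at this place, since compound 2 differs from compound 1 in more than one place and could not show it. The place therefore accepts both arrangements of the same atoms on the pyridine ring without a change that can be told from the scatter, and nothing available explains this result.

The compounds shown leave open whether the ring nitrogen or the two methyl groups matter at this place, which a dimethylphenyl group or an unsubstituted pyridin-3-yl group would address. Going by these compounds alone, they also do not separate the contributions to the gap between compound 1 and compound 2, as no single-change pair links the chain on the shared core to the hydroxy-bearing pyridine ring.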